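Changing the benzyl group on sulfur in compound 3

The compounds below may be only part of what the source reports. "The series", "measured", "known", "first", "only" and "open" are said of these compounds alone.

In a functional assay on SW 1116 cells (Homo sapiens) for antiproliferative activity, read by MTT assay, with a stated time of 24 h (on this read-out higher numbers stand for weaker inhibition and lower numbers for stronger inhibition), compound 1 `Sc1nnc(-c2ccc3c(c2)OCCO3)n1-c1ccccc1` gives 38400 nM. Compound 2 `Clc1cccc(CSc2nnc(-c3ccc4c(c3)OCCO4)n2-c2ccccc2)c1` gives 10600 nM, and compound 3 `Cc1ccc(CSc2nnc(-c3ccc4c(c3)OCCO4)n2-c2ccccc2)cc1` gives 16200 nM. Compound 3 therefore stands clearly lower than compound 1, which means stronger inhibition, while it cannot be told apart from compound 2.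

Compound 4 `Fc1cccc(F)c1CSc1nnc(-c2ccc3c(c2)OCCO3)n1-c1ccccc1` keeps everything in compound 3 except one group: 2,6-difluorophenyl in place of 4-methylphenyl on a saturated chain carbon bound to a sulfur.

Replacing the hydrogen on the sulfur with a benzyl group gave modest steps, a 3.6-fold lower number from compound 1 to compound 2 (0.56 log units; beyond the scatter) and a 2.4-fold lower number from compound 1 to compound 3 (0.37 log units; beyond the scatter). Compound 4 keeps a benzyl group there, so these steps say little about the new change. The closest guide is the exchange of one substituted phenyl for another, a 1.5-fold higher number from compound 2 to compound 3 (0.18 log units; within the scatter). On that single precedent, no step beyond the scatter is expected in this assay. The estimated step is a 1.2-fold lower number from compound 3 to compound 4 (0.10 log units; within the scatter). The expected value for compound 4 is 13000 nM, with an estimated range from 6000 nM to 28000 nM.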

Compound 4, half-maximal inhibitory concentration: 9010 nM
Compound 4: middle estimate off by 1.4-fold (0.16 log units), on the high side; the range from low to high includes it.
By their numbers in this assay, from the lowest: compounds 4, 2 and 3 (each within the scatter of the next); then compound 1.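

In this assay both a 1.8-fold lower number from compound 3 to compound 4 (0.25 log units; within the scatter) and a 1.2-fold lower number from compound 2 to compound 4 (0.07 log units; within the scatter) show that 2,6-difluorophenyl, with two fluorines on the ring, cannot be told apart from 4-methylphenyl or 3-chlorophenyl on this saturated chain carbon bound to a sulfur. The 2,6-difluorobenzyl group also stands apart from the hydrogen on sulfur with a 4.3-fold lower number from compound 1 to compound 4 (0.63 log units; beyond the scatter) and so gives a third benzyl example of that modest step. Nothing shown here explains these results.

Going by these compounds, what an unsubstituted phenyl, a phenyl carrying a carboxylic acid or an amine, or a longer chain between the sulfur and the ring would do remains open. On these data alone, whether any such group could move the number beyond the scatter from compound 2, compound 3 and compound 4 also remains unknown.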